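The source may hold more compounds than are shown below. What is called first, only, known or untested is meant among the compounds shown, and "the series" means these compounds.

Measured in a functional assay on KM12 cells (Homo sapiens) for inhibition; a higher number here means a weaker inhibitor of growth, a lower number a stronger inhibitor of growth:
- compound 1 `COc1cccc(/C=C/c2ccc(S(N)(=O)=O)cc2)c1`: 12200 nM
- compound 2 `NS(=O)(=O)c1ccc(/C=C/c2ccc(F)cc2)cc1`: 16300 nM
- compound 3 `NS(=O)(=O)c1ccc(/C=C/c2cccc(O)c2)cc1`: 35400 nM

Compound 2 stands level with compound 1 within the scatter, while compound 3 has a higher number, beyond the scatter. Compound 4 `CN(C)c1ccc(/C=C/c2ccc(S(N)(=O)=O)cc2)cc1` carries dimethylamino in place of fluoro on an aromatic carbon, para to a large group: dimethylamino in place of fluoro on an aromatic carbon. Within the data shown here, the only measured step, a 2.9-fold higher number from compound 1 to compound 3 (0.46 log units; beyond the scatter), involves a different change and so bears on this one only loosely. It does show that a single change among these compounds can shift the number modestly. Among the measured compounds shown here, no measured step replaces fluoro, so no step beyond the scatter is expected in this assay. The estimated step is a 1.4-fold lower number from compound 2 to compound 4 (0.13 log units; within the scatter). For compound 4 the estimated value is 12000 nM, with an expected range from 3000 nM to 40000 nM.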

Compound 4, concentration for 50% growth inhibition: 8280 nM
Compound 4: the middle estimate sits 1.4-fold (0.16 log units) above what was measured; the measured number falls inside the stated range.
By their numbers in this assay, from the lowest: compounds 4, 1 and 2 (each within the scatter of the next); then compound 3.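

Replacing fluoro with dimethylamino on an aromatic carbon, para to a large group, gives in this assay a 2.0-fold lower number from compound 2 to compound 4 (0.29 log units; within the scatter) and so stays level with compound 2. At this position, then, 3 heavy atoms including a hydrogen-bond acceptor can stand in place of a single fluorine without a step beyond the scatter. No supporting evidence accounts for this outcome. Going by these compounds, whether a carboxylic acid or a primary amine in the same place would give a step beyond the scatter remains open.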